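Replacing the methyl group of compound 3

A few compounds are considered here, and "the series" means these few. Any claim that something is new, unique, unknown or untested is made for them only; others in the source may bear on it.

Within the data shown here, in a physicochemical assay for lipophilicity, at pH 7.4 (on this read-out higher numbers stand for higher lipophilicity and lower numbers for lower lipophilicity), compound 3 (`COc1cc2[nH]c(C)c(C)c(=O)c2cc1Cl`) gives 1.86, the lowest of the three numbers so far. Compound 1 (`COc1ccc2c(=O)c(Cc3ccccc3)c(C)n(C)c2c1`) is nearest at 3.24, and compound 2 (`CCCCCCCCCc1c(C)[nH]c2cc(OC)c(Cl)cc2c1=O`) is furthest at 4.74, both beyond the scatter. Compound 4 (`C=C(CCCCC)c1c(C)[nH]c2cc(OC)c(Cl)cc2c1=O`) differs from compound 3 as follows: a group of 7 heavy atoms (7 carbon; no ring) in place of one carbon atom, on an aromatic carbon. The entering group holds 1 double bond outside aromatic rings. Among the measured compounds shown here, one measured step bears on this change: a number 2.88 log units lower from compound 2 to compound 3 (beyond the scatter). Read in reverse, that step removes octyl, which is larger than the group gained here, so a large upward step in this assay is expected, though somewhat smaller. The expected result is a number 2.04 log units higher from compound 3 to compound 4 (beyond the scatter). For compound 4 the estimate is 3.9, within a range of 3.4 to 4.4.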

Compound 4, distribution coefficient: 3.58
The estimate for compound 4 lay 0.32 log units above the measured number; low and high end bracket the measured number.
By their numbers in this assay, from the lowest: compound 3; then compound 1; then compound 4; then compound 2.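

Swapping the methyl group on this aromatic carbon for a chain of 7 heavy atoms with 1 double bond gives a number 1.72 log units higher from compound 3 to compound 4 (beyond the scatter) in this assay, so this position also carries a large step when a chain enters in place of methyl. Among the chain-bearing compounds, compound 4 gives 3.58 and compound 2 gives 4.74 as printed. Nothing available explains the size of this step.

As far as these compounds go, whether an amine or a carboxylic acid here would move the number in the same direction remains open. A saturated hexyl-length chain would be needed to separate chain length from the double bond.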